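Para substituent swap on the phenyl of compound 3

A few compounds are considered here, and "the series" means these few. Any claim that something is new, unique, unknown or untested is made for them only; others in the source may bear on it.

Of the compounds shown here, three of the shared core have been measured in an assay on CHO cells for displacement of a labelled ligand from adenosine receptor A1 (Homo sapiens), read by scintillation counting, with a stated time of 3 h; a lower number here means a stronger inhibitor, a higher number a weaker inhibitor. Compound 1 `Cn1c(-c2ccc(O)cc2)nc2c(NC3CCCC3)ncnc21` gives 17 nM. Compound 2 `Cn1c(-c2cccnc2)nc2c(NC3CCCC3)ncnc21` gives 242 nM. Compound 3 `Cn1c(-c2ccc(Cl)cc2)nc2c(NC3CCCC3)ncnc21` gives 18 nM. Compound 3 stands second highest of the three numbers; its nearest neighbour is compound 1, since a 1.1-fold higher number from compound 1 to compound 3 (0.02 log units; within the scatter), and its furthest is compound 2, since a 13-fold lower number from compound 2 to compound 3 (1.13 log units; beyond the scatter). The other large movement in the set is a 14-fold higher number from compound 1 to compound 2 (1.15 log units; beyond the scatter), where the whole ring changes rather than a substituent on it.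

Compound 4 `Cc1ccc(-c2nc3c(NC4CCCC4)ncnc3n2C)cc1` differs from compound 3 in one place: methyl in place of chloro on an aromatic carbon. Among the compounds with values here, the step that bears most directly on this change is the one between compound 1 and compound 3, where hydroxy was replaced by chloro on the aromatic carbon and the number hardly moved: a 1.1-fold higher number from compound 1 to compound 3 (0.02 log units; within the scatter). The two large steps both involve pyridin-3-yl and do not speak to a substituent swap on a carbon-only ring. With two different groups at this position already giving numbers within the scatter of each other, no step beyond the scatter is expected in this assay for compound 4. The step from compound 3 is thus estimated as a 1.1-fold higher number from compound 3 to compound 4 (0.05 log units; within the scatter). Compound 4 is expected to give 20 nM, with a range of 8 nM to 50 nM.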

Compound 4, inhibition constant: 8 nM
The estimate for compound 4 lay 2.5-fold (0.40 log units) above the measured number; low and high end bracket the measured number.
By their numbers in this assay, from the lowest: compound 4; then compounds 1 and 3 (each within the scatter of the next); then compound 2.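

Methyl in place of chloro gives a 2.3-fold lower number from compound 3 to compound 4 (0.35 log units; beyond the scatter) and methyl in place of hydroxy gives a 2.1-fold lower number from compound 1 to compound 4 (0.33 log units; beyond the scatter) in this assay at this aromatic carbon para to a large group, so both steps are modest but beyond the scatter, whereas the earlier change from hydroxy to chloro stayed within it. The position therefore responds to the choice of substituent on the ring of carbon only, even though chloro and methyl have the same count of one heavy atom and no hydrogen-bond donors or acceptors. The step of a 30-fold lower number from compound 2 to compound 4 (1.48 log units; beyond the scatter) is the widest in the series, and its steps to all three other compounds make compound 4 the strongest inhibitor of the four. No available measurement bears on why methyl differs here from chloro or hydroxy.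

The compounds shown leave open how ethyl, a longer chain, methoxy, an amine or a carboxylic acid at this place would compare with methyl. They also leave open whether the step from chloro to methyl keeps its size when another part of the shared core changes.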